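The source may hold more compounds than are shown below. What is called first, only, known or untested is meant among the compounds shown, and "the series" means these compounds.

Measured compounds in an ADME assay on cells for inhibition of anoctamin-2 (Homo sapiens), read by fluorescence, with a stated time of 20 min; a lower number here means a stronger inhibitor, a higher number a weaker inhibitor:
Compound 1 `COc1cccc(-c2nnc(COc3ccc(Cl)cc3C)o2)c1` gives > 100000 nM.
Compound 2 `COc1cccc(/C=N/NC(=O)COc2ccc(Cl)cc2C)c1` gives "not active" (no number reported).
Compound 3 `Cc1cc(Cl)ccc1OCC(=O)N/N=C/c1ccccn1` gives > 100000 nM.

The value of compound 1 is a limit of the assay and not a number. Compound 3 likewise sits at a limit in this assay. Compound 2 returned no number at all. Compound 1 therefore stands among entries that give nothing to rank, as the limit of > 100000 nM in this assay, at which 2 of the 3 values shown sit, shows: none of the three measured compounds produced a measurable inhibition.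

Compound 4 `Cc1cc(Cl)ccc1OCc1nnc(-c2cccc(F)c2)o1` differs from compound 1 in one place: fluoro in place of methoxy on an aromatic carbon. The position is meta to a large group on the six-membered carbon-only aromatic ring, with the shared core of compound 1 otherwise unchanged. Among the compounds with values here, no step between measured compounds is available, so the size of this change can only be expected, not read from a measurement. With compound 1 at a limit in this assay and the series showing no measurable inhibitor so far, a step beyond the scatter is not expected in either direction. The step expected is a step that the limit leaves unreadable from compound 1 to compound 4, that is, none beyond the usual scatter. For compound 4 the expected value in this assay is 150000 nM, within 50000 nM to 500000 nM, most likely reported again only as a limit.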

Compound 4, half-maximal inhibitory concentration: > 100000 nM
Compound 4: a limit, no number; the forecaster's own chance of this, stated with the estimate: 80%; the middle value does not contradict the limit.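

Compound 1 and compound 4 both sit at a limit in this assay, so no step can be read for fluoro in place of methoxy on an aromatic carbon: the limit of > 100000 nM in this assay, at which 3 of the 4 values shown sit. The compounds shown leave open whether any change to the shared core gives measurable inhibition.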